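Working notes: replacing 2,6-dimethoxyphenyl in compound 2

A few compounds are considered here, and "the series" means these few. Any claim that something is new, unique, unknown or untested is made for them only; others in the source may bear on it.

Compound 1 `O=C(Cc1csc2nc(-c3ccc(Br)cc3)cn12)N/N=C/c1ccccc1O` gives 3240 nM
Compound 2 `COc1cccc(OC)c1/C=N/NC(=O)Cc1csc2nc(-c3ccc(Br)cc3)cn12` gives 15800 nM

Among the compounds with values here, in a functional assay on OVCAR-3 cells (Homo sapiens) for inhibition, read by sulforhodamine B assay, with a stated time of 48 h (on this read-out lower numbers stand for stronger inhibition of growth and higher numbers for weaker inhibition of growth), compound 2 has the highest of the two numbers so far. The change under review leads to compound 3 `O=C(Cc1csc2nc(-c3ccc(Br)cc3)cn12)N/N=C/c1ccc(Cl)cc1Cl` and puts 2,4-dichlorophenyl in place of 2,6-dimethoxyphenyl on a carbon with a double bond to nitrogen. One measured step, at the same place, bears on it (a 4.9-fold higher number from compound 1 to compound 2 (0.69 log units; beyond the scatter)). That step is modest and beyond the scatter. Within the data shown here, it compares only two groups, and no chlorine-bearing group has been measured, so the support is thin. A modest move to a lower number in this assay is expected, with the value remaining short of compound 1 or close to it. The expected step is modest (a 2.6-fold lower number from compound 2 to compound 3 (0.42 log units; beyond the scatter)). The estimate for compound 3 is 6000 nM (expected range 2000 nM to 18000 nM).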

Compound 3, concentration for 50% growth inhibition: 34700 nM
Estimate against measurement, compound 3: 5.8-fold (0.76 log units) below; measured number outside the range, above it.
By their numbers in this assay, from the lowest: compound 1; then compound 2; then compound 3.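

In this assay, the 2,4-dichlorophenyl group moves the number further from that of compound 1, not back towards it: the data show a 2.2-fold higher number from compound 2 to compound 3 (0.34 log units; beyond the scatter) and, against the 2-hydroxyphenyl group, an 11-fold higher number from compound 1 to compound 3 (1.03 log units; beyond the scatter) on the same shared core. Losing the two methoxy groups of compound 2 therefore does not by itself restore growth inhibition, and this position now separates three groups, with the order compound 1, compound 2, compound 3 from the lowest number. No measurement at hand explains this order.

Still open, from the compounds shown here alone, is whether an amine in place of the hydroxyl of compound 1 would keep its number. An unsubstituted phenyl or a phenyl bearing a carboxylic acid would also show how much of the spread depends on the substituents at all.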